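The source may report more compounds than this note shows. Statements on the series, on what has been measured and on what is new or still open speak of the compounds shown alone.

In a physicochemical assay for solubility, in phosphate buffer, at pH 7.4 (on this read-out lower numbers stand for lower solubility and higher numbers for higher solubility), three compounds sharing one core have been measured. Compound 1 `CC(=O)N[C@@H]1CCC[C@H](C(=O)Nc2cc(-c3cnc(C)n3C)c(Cl)cn2)C1` gives > 1000000 nM, which is a limit of the assay and not a number. Compound 2 `CC(=O)N[C@@H]1CCC[C@H](C(=O)Nc2cc(-c3cnc4ccccn34)c(Cl)cn2)C1` gives 120000 nM. Compound 3 `CC(=O)N[C@@H]1CCC[C@H](C(=O)Nc2cc(-c3cnc4n3CCC4)c(Cl)cn2)C1` gives 490000 nM, the higher of the two actual numbers.

Compound 4 `CC(=O)N[C@@H]1CCC[C@H](C(=O)Nc2cc(-c3cnn4c3CCCCC4)c(Cl)cn2)C1` changes one group of compound 3: a group of 10 heavy atoms (8 carbon, 2 nitrogen; one five-membered aromatic ring with 2 hetero atoms, one seven-membered non-aromatic ring with 1 hetero atom) in place of a group of 8 heavy atoms (6 carbon, 2 nitrogen; one five-membered non-aromatic ring with 1 hetero atom, one five-membered aromatic ring with 2 hetero atoms), on an aromatic carbon.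

All three measured steps alter this same group. The number fell in an at least 8.3-fold lower number from compound 1 to compound 2 (0.92 log units; beyond the scatter), where the group gained heavy atoms. It rose in a 4.1-fold higher number from compound 2 to compound 3 (0.61 log units; beyond the scatter), where the group lost them. The step of an at least 2.0-fold lower number from compound 1 to compound 3 (0.30 log units; that floor lies within the scatter) gives only a floor. Across these three compounds, then, the number drops as the group grows, and none of them goes against this. Compound 4 carries the biggest group so far, but its seven-membered non-aromatic ring is not aromatic, unlike the six-membered aromatic ring of compound 2. A modest fall is therefore expected, an estimated 2.2-fold lower number from compound 3 to compound 4 (0.35 log units; beyond the scatter).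

For compound 4, the expected value is 220000 nM, with an estimated range from 70000 nM to 600000 nM.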

Compound 4, solubility: 104000 nM
Estimate against measurement, compound 4: 2.1-fold (0.33 log units) above; measured number inside the range.
By their numbers in this assay, from the lowest: compounds 4 and 2 (each within the scatter of the next); then compound 3. At a limit, above all of these: compound 1.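

Replacing the group with a five-membered non-aromatic ring by the one with a seven-membered non-aromatic ring gives a 4.7-fold lower number from compound 3 to compound 4 (0.67 log units; beyond the scatter), so at this position, opposite the ring nitrogen, a non-aromatic ring does not by itself keep the number high. Replacing the group with a six-membered aromatic ring by the same seven-membered group gives a 1.2-fold lower number from compound 2 to compound 4 (0.06 log units; within the scatter), so these two different groups cannot be told apart on this read-out. The step of an at least 9.6-fold lower number from compound 1 to compound 4 (0.98 log units; beyond the scatter) leaves the smallest group on top, but it gives only a floor, as the value of compound 1 is a limit and not a number: the limit of > 1000000 nM in this assay, at which 1 of the 4 values shown sits.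

Going by these compounds, whether a six-membered non-aromatic ring in this group would give a number between those of compound 3 and compound 4 remains open. Also open, on these data alone, is what an amine or a hydroxyl on the non-aromatic ring would do.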